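The source may report more compounds than this note shows. Statements on the series, on what has been measured and on what is new or still open speak of the compounds shown alone.

Three compounds that share one core and differ only in the group on a ring nitrogen have been measured in an assay on Huh-7 cells for agonist activity at Bile acid receptor (Homo sapiens), read by a luciferase reporter; a lower number here means that less compound is needed, a higher number that more compound is needed for the effect. Compound 1 `CCC(CC)n1c(-c2ccc(OCc3c(-c4c(Cl)cccc4Cl)noc3C(C)C)cc2)nc2ccc(C(=O)O)cc21` carries a pentan-3-yl group there and in this assay compound 1 gives 0.8 nM. Compound 2 `CC(C)c1onc(-c2c(Cl)cccc2Cl)c1COc1ccc(-c2nc3ccc(C(=O)O)cc3n2CC(C)(C)C)cc1` carries a neopentyl group, and compound 2 gives 13 nM. Compound 3 `CC(C)c1onc(-c2c(Cl)cccc2Cl)c1COc1ccc(-c2nc3ccc(C(=O)O)cc3n2CC2CCCCC2)cc1` carries a cyclohexylmethyl group, and compound 3 gives 0.52 nM. Among these three numbers compound 3 has the lowest, but one of the gaps is small (a 1.5-fold lower number from compound 1 to compound 3 (0.19 log units; within the scatter)), whereas another is large (a 25-fold lower number from compound 2 to compound 3 (1.40 log units; beyond the scatter)), as is the third (a 16-fold higher number from compound 1 to compound 2 (1.21 log units; beyond the scatter)).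

Compound 4 `CC(C)c1onc(-c2c(Cl)cccc2Cl)c1COc1ccc(-c2nc3ccc(C(=O)O)cc3n2C2CCCC2)cc1` takes the next step: cyclopentyl in place of cyclohexylmethyl on an aromatic nitrogen. Going by the values given here, no measured step exchanges a group that is joined to the nitrogen through a chain carbon for a ring joined directly to the nitrogen, so the measured steps guide only loosely. Compound 1, which also has its branching point directly on the nitrogen, gives 0.8 nM, and both small and large shifts have been seen here. The change from compound 3 to compound 4 is therefore expected to be modest, a 2.9-fold higher number from compound 3 to compound 4 (0.46 log units; beyond the scatter). For compound 4 in this assay the estimate is 1.5 nM, within a range from 0.4 nM to 6 nM.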

Compound 4, half-maximal effective concentration: 13.6 nM
Beside the measured number, compound 4's estimate is 9.1-fold (0.96 log units) below it, outside the stated range (above it).
By their numbers in this assay, from the lowest: compounds 3 and 1 (each within the scatter of the next); then compounds 2 and 4 (each within the scatter of the next).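

In this assay, a 26-fold higher number from compound 3 to compound 4 (1.42 log units; beyond the scatter) stands as a large step, so carrying a saturated carbon ring on this aromatic nitrogen does not by itself keep the number low; a ring joined through a chain carbon and a smaller ring joined directly behave very differently here. Having the branching point directly on the nitrogen is not enough either, since compound 1 and compound 4 both have it and a 17-fold higher number from compound 1 to compound 4 (1.23 log units; beyond the scatter) is also large. Meanwhile a 1.0-fold higher number from compound 2 to compound 4 (0.02 log units; within the scatter) lies within the scatter, so the open-chain neopentyl and the cyclic cyclopentyl cannot be told apart in this assay, and nothing measured so far accounts for any of these steps.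

Two things changed at once between compound 3 and compound 4, the size of the ring and the carbon linking it to the nitrogen, and the compounds shown do not separate them. Cyclopentylmethyl, which keeps the linking carbon with the smaller ring, and cyclohexyl, which keeps the larger ring joined directly to the nitrogen, would each isolate one of those two changes.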